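Cyanoguanidine analogues at the histamine H2 receptor: working notes

The compounds below may be only part of what the source reports. "The series", "measured", "known", "first", "only" and "open" are said of these compounds alone.

Compound 1 `CN/C(=N/C#N)NCCCc1c[nH]c(C)n1` and compound 2 `Cc1nc(CCCN/C(=N\C#N)NCCSc2ccccc2)c[nH]1` share one core; compound 3 `CN/C(=N/C#N)NCCCCc1nc(N)n[nH]1` carries another, and the difference between the two cores is not broken down here. In a functional assay on Sf9 cells for antagonist activity at histamine H2 receptor (Homo sapiens), read by scintillation counting and GTPgammaS binding, with a stated time of 90 min (a lower number here means a less potent compound, a higher number a more potent compound, by a factor of ten per unit of this negative logarithm), compound 1 gives < 5, a limit of the assay. In this assay compound 2 gives < 5, likewise a limit. Compound 3 gives < 5 in this assay, again a limit. The step that the two limits leave unreadable from compound 1 to compound 2 cannot be sized because the limit of < 5 in this assay, at which 3 of the 3 values shown sit, leaves no readable number on either side. Compound 2 differs from compound 1 by (phenylsulfanyl)methyl in place of hydrogen on a saturated chain carbon bound to an amine nitrogen. Compound 4 `N#C/N=C(\NCCCCc1nc(N)n[nH]1)NCCSc1ccccc1` differs from compound 3 by the same change, ((phenylsulfanyl)methyl in place of hydrogen on a saturated chain carbon bound to an amine nitrogen). The step from compound 3 to compound 4 is expected to be a number no lower from compound 3 to compound 4 (the limit leaves the size open) in this assay, resting only on a step that the two limits leave unreadable from compound 1 to compound 2, which gave no sign of a gain. Compound 4 is therefore estimated at about 5, between 4.3 and 5.8, with a fair chance that only a limit is again reported.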

Compound 4, negative logarithm of the antagonist equilibrium constant: < 5
Compound 4 ended at the assay's limit; the forecaster's own chance of this, stated with the estimate: 60%; the middle value sits exactly at the limit.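

Among the compounds shown here, no step linking compound 4 to compound 2 or compound 3 can be read: the limit of < 5 in this assay, at which 4 of the 4 values shown sit. The compounds shown leave open what the (phenylsulfanyl)methyl change does to potency, and how far each compound lies from that limit.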